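Ester to Amino Acid Amide at the Carbonyl Carbon

The source may hold more compounds than are shown below. What is called first, only, known or untested is meant among the compounds shown, and "the series" means these compounds.

Measured compounds in an assay on cells for agonist activity at vitamin D3 receptor (Homo sapiens), with a stated time of 96 h; on this read-out lower numbers stand for an effect already at smaller amounts and higher numbers for an effect only at larger amounts of compound:
Compound 1, `CCn1c(C(=O)NCC#N)ccc1C(CC)(CC)c1ccc(OCCC(O)(CC)CC)c(C)c1`, gives 1080 nM.
Compound 2, `C#CC(C)OC(=O)c1ccc(C(CC)(CC)c2ccc(OCCC(O)(CC)CC)c(C)c2)n1CC`, gives 2650 nM.
Compound 3, `CCC(C)C(NC(=O)c1ccc(C(CC)(CC)c2ccc(OCCC(O)(CC)CC)c(C)c2)n1CC)C(=O)O`, gives 860 nM.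

Compound 2 has the highest number of the three. Its nearest neighbour is compound 1, with a 2.5-fold higher number from compound 1 to compound 2 (0.39 log units; beyond the scatter), and its furthest is compound 3, with a 3.1-fold lower number from compound 2 to compound 3 (0.49 log units; beyond the scatter). Compounds 1 and 3 both carry an amide at the carbonyl carbon, and between them a 1.3-fold lower number from compound 1 to compound 3 (0.10 log units; within the scatter), so the two amides sit together while the ester of compound 2 stands apart.

Compound 4, `CCn1c(C(=O)NC(C)C(=O)O)ccc1C(CC)(CC)c1ccc(OCCC(O)(CC)CC)c(C)c1`, is not yet measured. It differs from compound 2 by (1-carboxyethyl)amino in place of (1-methylprop-2-yn-1-yl)oxy on a carbonyl carbon. This change again replaces the ester with an amide bearing a carboxylic acid, as in the step from compound 2 to compound 3. That step, a 3.1-fold lower number from compound 2 to compound 3 (0.49 log units; beyond the scatter), is the one that bears most directly on it, and the smaller cyanomethyl amide of compound 1 fell close to compound 3. A lower number for compound 4 in this assay is therefore expected, with the step estimated as a 2.7-fold lower number from compound 2 to compound 4 (0.42 log units; beyond the scatter). The estimate for compound 4 is 1000 nM, in a range from 400 nM to 2500 nM.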

Compound 4, half-maximal effective concentration: 66 nM
Estimate against measurement, compound 4: 15-fold (1.18 log units) above, outside the stated range (below it).
By their numbers in this assay, from the lowest: compound 4; then compounds 3 and 1 (each within the scatter of the next); then compound 2.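

In this assay, for the compounds shown here, swapping the ester for an amide bearing a carboxylic acid can do far more at this carbonyl carbon than the earlier compounds suggested: (1-carboxyethyl)amino gives a 40-fold lower number from compound 2 to compound 4 (1.60 log units; beyond the scatter) in this series. The group on the saturated chain carbon bound to the amide-type nitrogen and the carbonyl carbon matters greatly, since methyl in place of sec-butyl gives a 13-fold lower number from compound 3 to compound 4 (1.11 log units; beyond the scatter) even though both compounds carry the carboxylic acid. An amide alone does not explain the result either, as 1-carboxyethyl in place of cyanomethyl on the amide-type nitrogen gives a 16-fold lower number from compound 1 to compound 4 (1.21 log units; beyond the scatter) here.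

No measurement on hand gives a reason for these large steps. Going by these compounds, whether a plain hydrogen or an ethyl chain in place of that methyl, or an amine in place of the carboxylic acid, would keep the number this low remains open.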